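Methoxy in Place of Hydrogen on Compound 2

The source may report more compounds than this note shows. Statements on the series, on what has been measured and on what is new or still open speak of the compounds shown alone.

Measured compounds in a functional assay on cells (Cancer cell lines, Homo sapiens) for cytotoxicity, read by sulforhodamine B assay, with a stated time of 48 h; on this read-out higher numbers stand for weaker inhibition of growth and lower numbers for stronger inhibition of growth:
- compound 1 `O=C1N=C(N2N=C(c3ccccc3)CC2c2ccccc2O)S/C1=C1/C(=O)Nc2ccc(Br)cc21` gives 280 nM
- compound 2 `COc1ccc(C2CC(c3ccccc3)=NN2C2=NC(=O)/C(=C3\C(=O)Nc4ccc(Br)cc43)S2)cc1` gives 230 nM

For the measured compounds named here, compound 2 holds the lowest of the two numbers, but its only neighbour, compound 1, sits apart by just a 1.2-fold lower number from compound 1 to compound 2 (0.09 log units; within the scatter), a step within the scatter, so no order between the two can be claimed. Compound 3 `COc1ccc(C2=NN(C3=NC(=O)/C(=C4\C(=O)Nc5ccc(Br)cc54)S3)C(c3ccc(OC)cc3)C2)cc1` differs from compound 2 by methoxy in place of hydrogen on an aromatic carbon of a six-membered aromatic ring of carbon only, para to a large group; cut one bond further out this reads phenyl to 4-methoxyphenyl. Going by the values given here, the single measured step that bears on it is the one from compound 1 to compound 2, where 4-methoxyphenyl replaced 2-hydroxyphenyl on a saturated ring carbon, and that step stayed within the scatter. Among the compounds with values here, no measured step adds a methoxy to the ring changed here. The expectation is therefore no step beyond the scatter, estimated as no change at the digits printed from compound 2 to compound 3 (within the scatter). Compound 3 is expected near 230 nM, within a range from 110 nM to 480 nM.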

Compound 3, concentration for 50% growth inhibition: 240 nM
The estimate for compound 3 lay 1.0-fold (0.02 log units) below the measured number; measured number inside the range.
By their numbers in this assay, from the lowest: compounds 2, 3 and 1 (each within the scatter of the next).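

In this assay, for the compounds shown here, going from phenyl to 4-methoxyphenyl gives a 1.0-fold higher number from compound 2 to compound 3 (0.02 log units; within the scatter), and this is the first reading on this ring, since the earlier step changed only the aryl group on the saturated ring carbon. So an aromatic carbon para to a large group can carry a methoxy, with its 2 heavy atoms and 1 hydrogen-bond acceptor, without a difference that this read-out can separate from the scatter; the result is a tolerated change at this one position in this cell test, not a gain or a loss. Nothing available here explains why the two compounds read alike.

The compounds shown leave open how far this tolerance extends: a dimethylamino group, a carboxylic acid or a longer chain such as butoxy at the same carbon might or might not stay within the scatter of compound 2. They also leave open whether a methoxy at this position would read the same way if the aryl group on the saturated ring carbon were the 2-hydroxyphenyl of compound 1.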